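Removing a ring methyl from a fatty acid transport inhibitor

The compounds below may be only part of what the source reports. "The series", "measured", "known", "first", "only" and "open" are said of these compounds alone.

The measured pair here is small. Compound 1 `CC1CCc2sc(NC(=O)CN3CCN(c4ccc(F)cc4)CC3)nc2C1` gives 5100 nM in an assay on isolated protein for inhibition of long-chain fatty acid transport protein 1 (Mus musculus), read by scintillation counting, with a stated time of 20 min (on this read-out higher numbers stand for weaker inhibition and lower numbers for stronger inhibition), the highest of the two numbers. For the measured compounds named here, compound 2 `O=C(CN1CCN(c2ccc(F)cn2)CC1)Nc1nc2c(o1)CCCC2` differs from compound 1 in its core and in its aryl ring, so no single step between them is counted; in this assay compound 2 gives 1700 nM, a lower number than compound 1 by more than the scatter.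

Compound 3 `O=C(CN1CCN(c2ccc(F)cc2)CC1)Nc1nc2c(s1)CCCC2` is reached from compound 1 by one change: hydrogen in place of methyl on a saturated ring carbon. Going by the values given here, nothing among the measured compounds tells how a methyl at that place matters, so the expectation for this step rests only on its size. One carbon with no ring, donor, acceptor or charge is expected to shift the number little, most likely to a slightly lower value, but not beyond the scatter.

Compound 3 is therefore estimated at 3800 nM, within 1600 nM to 9000 nM, an expected step of a 1.3-fold lower number from compound 1 to compound 3 (0.13 log units; within the scatter).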

Compound 3, half-maximal inhibitory concentration: 4000 nM
Compound 3: middle estimate off by 1.1-fold (0.02 log units), on the low side, within the range that was stated.
By their numbers in this assay, from the lowest: compound 2; then compounds 3 and 1 (each within the scatter of the next).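

In this assay, hydrogen in place of methyl on a saturated ring carbon comes to a 1.3-fold lower number from compound 1 to compound 3 (0.11 log units; within the scatter), so the two compounds cannot be told apart on this read-out. For the compounds shown here, this is the first direct reading of this position, which compound 1 and compound 2 could not give, as they differ in more than one place; here, the methyl can be removed with no change beyond the scatter. Nothing available explains why this methyl counts for so little.

On these data alone, whether the same ring carbon would accept a longer chain such as ethyl, a hydroxyl or an amine remains open. Also open, as far as these compounds go, is whether removing a methyl would read the same way on the core and aryl ring of compound 2.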